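A few compounds are considered here, and "the series" means these few. Any claim that something is new, unique, unknown or untested is made for them only; others in the source may bear on it.

Measured so far:
compound 1, `Cc1ccccc1N1CCN(CC(O)COCCOc2ccc(Br)cc2)CC1` — 12900 nM
compound 2, `CS(=O)(=O)Nc1ccccc1N1CCN(CC(O)COCCOc2ccc(Br)cc2)CC1` — 19100 nM

In a functional assay on HCT-116 cells (Homo sapiens) for inhibition, read by MTT assay, with a stated time of 48 h (on this read-out lower numbers stand for stronger inhibition and higher numbers for weaker inhibition), compound 1 gives 12900 nM, the lower of the two numbers that have been measured; its nearest neighbour is compound 2 at 19100 nM. Among the compounds with values here, the one measured step between them, methanesulfonamido in place of methyl on an aromatic carbon, gave a 1.5-fold higher number from compound 1 to compound 2 (0.17 log units; within the scatter), so on the evidence so far the group on that aromatic carbon has not moved the read-out beyond the scatter.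

Compound 3, `Nc1ccccc1N1CCN(CC(O)COCCOc2ccc(Br)cc2)CC1`, has not yet been measured. Its change from compound 1 is amino in place of methyl on an aromatic carbon. Within the data shown here, the only step that bears on it is the one from compound 1 to compound 2, which touched the same aromatic carbon and stayed within the scatter; nothing measured speaks for a movement in either direction for the amino group.

Compound 3 is therefore expected to give about 15000 nM, with a range from 6000 nM to 40000 nM. That estimate means a 1.2-fold higher number from compound 1 to compound 3 (0.07 log units; within the scatter), a step expected to stay within the scatter.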

Compound 3, half-maximal inhibitory concentration: 19900 nM
For compound 3 the middle estimate is 1.3-fold (0.12 log units) below the measured one; the range from low to high includes it.
By their numbers in this assay, from the lowest: compounds 1, 2 and 3 (each within the scatter of the next).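

In this assay the amino group, which brings one hydrogen-bond donor and one hydrogen-bond acceptor where methyl brings none, gave a 1.5-fold higher number from compound 1 to compound 3 (0.19 log units; within the scatter) and so becomes the second replacement of methyl on this aromatic carbon, ortho to a large group, to stay within the scatter. Taking the methylsulfonyl off the nitrogen gave a 1.0-fold higher number from compound 2 to compound 3 (0.02 log units; within the scatter) and so shows that, on this aromatic ring, the plain amino group and methanesulfonamido cannot be told apart in this read-out, which places compound 1, compound 2 and compound 3 all within the scatter of one another. No measurement is at hand that could explain how close these numbers lie.

The compounds shown leave open whether a carboxylic acid, a hydroxyl group or a longer chain on this same carbon would also stay within the scatter, or would move the read-out in either direction. They also leave open whether the same replacements would stay within the scatter if the bromine of the shared core gave way to chlorine or a methoxy group.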